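The compounds below may be only part of what the source reports. "The series", "measured", "known", "first", "only" and "open" are said of these compounds alone.

Compound 1 `COc1cc(/C(Cl)=C/C=C(\C#N)C(=O)c2c[nH]c3ccccc23)cc(OC)c1OC` belongs to a small set of three analogues that share one core and differ only in their methoxy groups. In a functional assay for inhibition, read by Griess assay, with a stated time of 150 min, tested at 1 mM (on this read-out higher numbers stand for more inhibition at the one concentration tested (going by the name of the read-out) and lower numbers for less inhibition), compound 1 gives 73.3%. Compound 2 `COc1ccc2[nH]cc(C(=O)/C(C#N)=C/C=C(\Cl)c3ccc(OC)c(OC)c3)c2c1` gives 74.2%, and compound 3 `COc1ccc(/C(Cl)=C/C=C(\C#N)C(=O)c2c[nH]c3ccccc23)cc1OC` gives 75%; both of these lie within the scatter of the number for compound 1, so no order among the three can be read from them. The two measured steps, a number 1.7 percentage points higher from compound 1 to compound 3 (within the scatter) and a number 0.8 percentage points higher from compound 2 to compound 3 (within the scatter), each replace a methoxy group with hydrogen and each stays within the scatter.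

Compound 4 `COc1cc(/C(Cl)=C/C=C(\C#N)C(=O)c2c(C)[nH]c3ccccc23)cc(OC)c1OC` differs from compound 1 elsewhere: methyl in place of hydrogen on an aromatic carbon, so that 1H-indol-3-yl becomes 2-methyl-1H-indol-3-yl. Among the measured compounds shown here, no measured step touches this part of the core; the methoxy steps bear on it only in showing that small changes to this series have left this assay flat. The step of a number 1.3 percentage points lower from compound 1 to compound 4 (within the scatter) is therefore expected to stay within the scatter. Compound 4 is estimated at 72%, with a range from 60% to 84%.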

Compound 4, a percentage reported as inhibition, at one concentration (the size of the read-out at that concentration, not a potency): 74.2%
Beside the measured number, compound 4's estimate is 2.2 percentage points below it; measured number inside the range.
By their numbers in this assay, from the lowest: compounds 1, 2, 4 and 3 (each within the scatter of the next).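

Placing methyl in place of hydrogen on the five-membered aromatic ring, next to the ring nitrogen, gives a number 0.9 percentage points higher from compound 1 to compound 4 (within the scatter) in this assay. Among the compounds shown here, the earlier steps changed only methoxy groups, so this is the first sign that this other part of the shared core can also carry a small added group with the number staying within the scatter. No measurement at hand explains this result.

On these data alone, a single methyl is only a small probe of this position, and it remains open whether a longer chain such as butyl, an amine or a carboxylic acid at the same carbon would also stay within the scatter. Since each number comes from one concentration, a shift in potency among these compounds also remains open.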